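A few compounds are considered here, and "the series" means these few. Any claim that something is new, unique, unknown or untested is made for them only; others in the source may bear on it.

Compound 1 `C=C1C=CC(=O)[C@@H]2[C@H](Cc3ccc(OCOC)cc3)CC[C@H]12`: 129 nM
Compound 2 `C=C1C=CC(=O)[C@@H]2[C@H](Cc3ccc(OC)c(F)c3)CC[C@H]12`: 1.11 nM

Both numbers come from a functional assay on HCT-116 cells (Homo sapiens) for antiproliferative activity, with a stated time of 72 h; a lower number here means a stronger inhibitor, a higher number a weaker inhibitor. Compound 1 has the higher number of the two, which makes it the weaker inhibitor, and its gap to compound 2 lies well beyond the usual scatter of repeated measurements. Compound 3 `C=C1C=CC(=O)[C@@H]2[C@H](Cc3ccc(O)cc3)CC[C@H]12` keeps the core of compound 1 and changes it in one place: hydrogen in place of methoxymethyl on an oxygen on an aromatic ring. Hydrogen takes the place of methoxymethyl on an oxygen on an aromatic ring, so methoxymethoxy becomes hydroxy.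

Within the data shown here, no two measured compounds differ in only one place, so the data give no direct size for this change. Among the measured compounds shown here, the only guide is compound 2, which reaches 1.11 nM with a different set of groups on its aromatic ring. This suggests that changes on that ring can shift the number strongly. A modest move toward a lower number is expected, small beside the gap between the two measured compounds. The expected change is a 2.6-fold lower number from compound 1 to compound 3 (0.41 log units; beyond the scatter). For compound 3 the estimated value is 50 nM, with an expected range from 10 nM to 250 nM.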

Compound 3, half-maximal inhibitory concentration: 38.5 nM
Beside the measured number, compound 3's estimate is 1.3-fold (0.11 log units) above it, and the stated range covers the measured number.
By their numbers in this assay, from the lowest: compound 2; then compound 3; then compound 1.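

In this assay, taking the methoxymethyl off the oxygen on the aromatic ring, so that methoxymethoxy becomes hydroxy, gives a 3.4-fold lower number from compound 1 to compound 3 (0.53 log units; beyond the scatter). Among these compounds, this is the first direct size for a single change, and it shows that the methoxymethyl is not needed for a number in this range: the compound with the bare hydroxy is the stronger inhibitor of the two, though the step is only modest. Among the compounds shown here, nothing measured so far says why removing this group lowers the number, so the step stands as an observation without an explanation.

Compound 2 differs from compound 1 and from compound 3 in more than one place, so the compounds shown cannot say how much of its low number comes from the methoxy group and how much from the fluorine on its ring. Going by these compounds, it also remains open how other groups on this same oxygen would compare, such as a methyl alone on an otherwise unchanged ring, an ethyl or an acetyl, and whether an amine could stand in place of the hydroxy.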